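Swapping Methyl for Fluoro on Two Inactive Sulfonamides

A few compounds are considered here, and "the series" means these few. Any claim that something is new, unique, unknown or untested is made for them only; others in the source may bear on it.

Of the compounds shown here, two of a sulfonamide series have been tested. Compound 1 `O=S(=O)(Nc1ccc2oc(-c3ccccc3)nc2c1)c1cccc(C(F)(F)F)c1` carries a trifluoromethyl group, while compound 2 `Cc1ccc(S(=O)(=O)Nc2ccc(-c3nc4ccccc4o3)cc2)cc1` carries a 4-methylphenyl group. Both were measured in an assay on cells for inhibition of HSP60/HSP10 (Homo sapiens), with a stated time of 60 min; on this read-out higher numbers stand for weaker inhibition and lower numbers for stronger inhibition. Compound 1 gives > 100000 nM, which is a limit of the assay rather than a number. Compound 2 gives > 100000 nM, likewise a limit of the assay and not a measured number. Compound 2 therefore stands at the weak end of everything shown so far, as the evidence makes plain: the limit of > 100000 nM in this assay, at which 2 of the 2 values shown sit.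

Compound 3 `O=S(=O)(Nc1ccc(-c2nc3ccccc3o2)cc1)c1ccc(F)cc1` has not yet been measured. It differs from compound 2 in a single place: fluoro in place of methyl on an aromatic carbon. Within the data shown here, no step between measured compounds exists to show what such an exchange does here, so the expectation rests on compound 2 alone. Compound 3 is expected to stay at or near the same limit, which means an estimated step from compound 2 to compound 3 of a step that the limit leaves unreadable from compound 2 to compound 3, not beyond the usual scatter. The estimate for compound 3 is 150000 nM, with a range from 40000 nM to 500000 nM.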

Compound 3, half-maximal inhibitory concentration: 73000 nM
Beside the measured number, compound 3's estimate is 2.1-fold (0.31 log units) above it; low and high end bracket the measured number.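

In this assay compound 3 gives 73000 nM, the only value among the three shown that is a number and not a limit of the assay, so this position on the 4-methylphenyl ring now has one readable result. Fluoro in place of methyl at this place gives an at least 1.3-fold lower number from compound 2 to compound 3 (0.13 log units; that floor lies within the scatter), which means the exchange can be described only by a floor, and that floor alone does not establish a real gain. The true size of the step stays unknown because compound 2 sits at a limit: the limit of > 100000 nM in this assay, at which 2 of the 3 values shown sit.

As far as these compounds go, what a chloro group, an amine or a longer chain would give at this same place remains open, so one exchange cannot show whether the read-out at this position follows any trend. Also open, from the compounds shown here alone, is whether fluoro in place of methyl would act the same way on another core, and compound 1 cannot help here, since it differs from compound 3 in more than one place.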